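Amide-side aryl exchange, compound 3 to compound 4

This account rests on a few compounds, and the source may have more. Where it says the series, first, only, none or still open, it means among the compounds named here.

Compound 3 `O=C(COc1ccc2cc(/C=C3/SC(=O)NC3=O)ccc2c1)Nc1cccc(C(F)(F)F)c1` gives 2500 nM in an assay on isolated protein for inhibition of histone deacetylase 4 (Homo sapiens), with a stated time of 1 h (on this read-out higher numbers stand for weaker inhibition and lower numbers for stronger inhibition), the highest of the three numbers obtained so far. Compound 1 `O=C(COc1ccc2cc(/C=C3/SC(=O)NC3=O)ccc2c1)Nc1ccc(Br)cc1F` gives 1900 nM in this assay, and compound 2 `Cc1cc(Br)ccc1NC(=O)COc1ccc2cc(/C=C3/SC(=O)NC3=O)ccc2c1` gives 550 nM. The step of a 1.3-fold higher number from compound 1 to compound 3 (0.12 log units; within the scatter) stays within the scatter, whereas a 4.5-fold higher number from compound 2 to compound 3 (0.66 log units; beyond the scatter) and a 3.5-fold lower number from compound 1 to compound 2 (0.54 log units; beyond the scatter) are modest but beyond it. Compound 4 `O=C(COc1ccc2cc(/C=C3/SC(=O)NC3=O)ccc2c1)Nc1c(F)cc(F)cc1Br` has not yet been measured; it carries 2-bromo-4,6-difluorophenyl in place of 3-(trifluoromethyl)phenyl on an amide-type nitrogen. The change brings back a bromine-bearing ring of the kind found in compound 1 and compound 2, whose numbers lie level with or below that of compound 3. Among the compounds with values here, no measured step matches this exact exchange, so the size is uncertain: a lowering anywhere between the near-flat a 1.3-fold higher number from compound 1 to compound 3 (0.12 log units; within the scatter) reversed and the modest 4.5-fold higher number from compound 2 to compound 3 (0.66 log units; beyond the scatter) reversed seems plausible. Compound 4 is therefore expected to give 1400 nM in this assay, with a range from 450 nM to 4500 nM. The expected step is a 1.8-fold lower number from compound 3 to compound 4 (0.25 log units; within the scatter).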

Compound 4, half-maximal inhibitory concentration: 1100 nM
For compound 4 the middle estimate is 1.3-fold (0.10 log units) above the measured one; the range from low to high includes it.
By their numbers in this assay, from the lowest: compounds 2, 4, 1 and 3 (each within the scatter of the next, the first and the last beyond it).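

On the amide-type nitrogen, the exchange to 2-bromo-4,6-difluorophenyl gives a 2.3-fold lower number from compound 3 to compound 4 (0.36 log units; beyond the scatter) in this assay, so this position responds to replacing 3-(trifluoromethyl)phenyl, which the step from compound 1 to compound 3 did not show beyond the scatter. Compound 4 also lies close to both other bromine-bearing compounds, with a 2.0-fold higher number from compound 2 to compound 4 (0.30 log units; within the scatter) and a 1.7-fold lower number from compound 1 to compound 4 (0.24 log units; within the scatter), although compound 1 and compound 2 are separated beyond the scatter. No measurement available here explains these differences.

Each exchange alters several ring substituents at once, so the separate contributions of the bromine, fluorine and methyl groups remain unresolved. Going by these compounds, it also remains open how an aromatic ring carrying an amine or a carboxylic acid would read out at this position.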